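Stereocentre drawn at compound 3: working notes

This account rests on a few compounds, and the source may have more. Where it says the series, first, only, none or still open, it means among the compounds named here.

Measured in an ADME assay on Caco-2 cells (Homo sapiens) for permeability, read by LC-MS, with a stated time of 2 h; on this read-out higher numbers stand for higher permeability and lower numbers for lower permeability:
- compound 1 `CCCN(Cc1ccc(OCCN2C(=O)CCC2=O)c(C)c1)[C@@H](CC(=O)O)c1ccc(Cl)cc1`: 9.3 nm/s
- compound 2 `Cc1cc(CN(CC2CC2)[C@@H](CC(=O)O)c2ccc(Cl)cc2)ccc1OCCN1C(=O)CCC1=O`: 7.3 nm/s
- compound 3 `Cc1cc(CN(CC2CCCC2)C(CC(=O)O)c2ccc(Cl)cc2)ccc1OCCN1C(=O)CCC1=O`: 28.9 nm/s

Compound 3 stands highest of the three (28.9 nm/s). Compound 1 gives 9.3 nm/s and compound 2 gives 7.3 nm/s. The gaps from compound 3 to each of these two lie beyond the scatter. Compounds 1 and 2 lie within the scatter of each other.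

Still unmeasured is compound 4 `Cc1cc(CN(CC2CCCC2)[C@@H](CC(=O)O)c2ccc(Cl)cc2)ccc1OCCN1C(=O)CCC1=O`, and its difference from compound 3 is the two compounds have the same atoms and bonds; at least one stereo element is drawn with a configuration in one of them and without one in the other: 1 of 1 stereo elements differ; a stereocentre at a saturated chain carbon is drawn without a configuration in compound 3 and S in compound 4. The atoms and bonds therefore stay the same, and only the drawing of the stereocentre at a saturated chain carbon differs.

Within the data shown here, the one measured step, a 1.3-fold lower number from compound 1 to compound 2 (0.11 log units; within the scatter), lies within the scatter, but it is a change of group and not of a stereocentre. Among the measured compounds shown here, no measured pair isolates a change of this kind, so the data give no direct size for it. With atoms and bonds unchanged, no step beyond the scatter is expected in this assay, and no direction is favoured. The expected step is a 1.1-fold lower number from compound 3 to compound 4 (0.03 log units; within the scatter) and should stay within the scatter. For compound 4 the estimated value is 27 nm/s, with an expected range (13 nm/s to 55 nm/s).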

Compound 4, apparent permeability: 18.1 nm/s
Beside the measured number, compound 4's estimate is 1.5-fold (0.17 log units) above it; the range from low to high includes it.
By their numbers in this assay, from the lowest: compounds 2, 1, 4 and 3 (each within the scatter of the next, the first and the last beyond it).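

In this assay, among these compounds, the first reading on a change of stereo drawing alone is a 1.6-fold lower number from compound 3 to compound 4 (0.20 log units; within the scatter), so at this saturated chain carbon the drawing alone gives no step beyond the scatter. Among the compounds shown here, with the S drawing held throughout, the group on the saturated chain carbon bound to an amine nitrogen can now be compared directly: cyclopentyl in place of cyclopropyl gives a 2.5-fold higher number from compound 2 to compound 4 (0.39 log units; beyond the scatter), the only one of these steps beyond the scatter, while cyclopentyl in place of ethyl gives a 1.9-fold higher number from compound 1 to compound 4 (0.29 log units; within the scatter). The step on the stereocentre therefore concerns a difference in drawing alone, with atoms and bonds the same, and the one structural fact available for reading it is: the fact that one of compounds 3 and 4 is drawn with a defined configuration and the other without, at the place where they differ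

The compounds shown leave open how the R drawing at this carbon would read in this assay, since neither compound 3 nor compound 4 is drawn that way. They also leave open whether cyclohexyl in place of cyclopentyl on a saturated chain carbon bound to an amine nitrogen would extend the step seen from cyclopropyl or fall within the scatter of compound 4.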